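One Carbon More on a Chain Already Free of Toxicity

The source may report more compounds than this note shows. Statements on the series, on what has been measured and on what is new or still open speak of the compounds shown alone.

Compound 1 `Nc1nc2c(ncn2/C=C2/CC2(CO)CO)c(=O)[nH]1`, compound 2 `Nc1nc(N2CCCC2)c2ncn(/C=C3/CC3(CO)CO)c2n1` and compound 3 `CCCNc1nc(N)nc2c1ncn2/C=C1/CC1(CO)CO` share one core and differ only in the group carried on the aromatic carbon. In an ADME assay on CCRF-HSB-2 cells (Homo sapiens) for cytotoxicity, with a stated time of 7 days (on this read-out lower numbers stand for higher toxicity in this test and higher numbers for lower toxicity in this test), compound 1 gives > 20000 nM, which is a limit of the assay and not a number. In this assay compound 2 gives > 20000 nM, likewise a limit. In this assay compound 3 gives > 20000 nM, again a limit. The step that the two limits leave unreadable from compound 2 to compound 3 cannot be read in size because of the limit of > 20000 nM in this assay, at which 3 of the 3 values shown sit. Compound 3 therefore stands at the limit, alongside the other two, with no number of its own. Compound 4 `CCCCNc1nc(N)nc2c1ncn2/C=C1/CC1(CO)CO` differs from compound 3 by methyl in place of hydrogen on a saturated chain carbon, three bonds along the chain from a nitrogen on an aromatic ring. Among the compounds with values here, no measured step bears directly on this change, and the one step available is itself unreadable. The step that the limit leaves unreadable from compound 3 to compound 4 is accordingly expected to be none beyond the scatter. Compound 4 is estimated at 30000 nM, within 15000 nM to 80000 nM, and is expected to come back once more as a limit rather than a number.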

Compound 4, half-maximal cytotoxic concentration: > 20000 nM
Compound 4 was reported as a limit; the forecaster's own chance of this, stated with the estimate: 85%; the middle value is on the limit's open side.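

Neither the step from compound 3 to compound 4 nor the step from compound 2 to compound 4 can be read in size: (the limit of > 20000 nM in this assay, at which 4 of the 4 values shown sit). The compounds shown leave open whether any group on the aromatic carbon of the shared core changes the read-out in this assay at all.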